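Series notes on the step from compound 1 to compound 4

A few compounds are considered here, and "the series" means these few. Any claim that something is new, unique, unknown or untested is made for them only; others in the source may bear on it.

Compound 1 `COc1ccc(/C=C\c2cc(OC)c(OC)c(OC)c2)cc1OCc1ccc(CN2CCCCC2C(=O)O)cc1` carries a 2-carboxypiperidin-1-yl group on a saturated chain carbon bound to an aromatic carbon of the shared core. In an ADME assay on NCM460 cells (Homo sapiens) for cytotoxicity, read by CCK-8 assay, with a stated time of 48 h (a higher number here means a weaker inhibitor, a lower number a stronger inhibitor), compound 1 gives only a limit, > 50000 nM, not a number. Compound 2 `COc1ccc(/C=C\c2cc(OC)c(OC)c(OC)c2)cc1OCc1ccc(CO)cc1` likewise returns only a limit in this assay, > 50000 nM. For the measured compounds named here, compound 3 `COc1ccc(/C=C\c2cc(OC)c(OC)c(OC)c2)cc1OCc1ccc(CNCCNC(C)=O)cc1` gives in this assay 54000 nM, the one value in the set that is a number. The three steps connecting them, a step that the two limits leave unreadable from compound 1 to compound 2, a step that the limit leaves unreadable from compound 1 to compound 3 and a step that the limit leaves unreadable from compound 2 to compound 3, are all unreadable in size, since each runs into or out of the limit of > 50000 nM in this assay, at which 2 of the 3 values shown sit. Going by the values given here, compound 1 therefore stands at that limit, with no measured step from it that can be sized.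

Compound 4 `COc1ccc(/C=C\c2cc(OC)c(OC)c(OC)c2)cc1OCc1ccc(CN2CC[C@@H](C(=O)O)C2)cc1` differs from compound 1 by 3-carboxypyrrolidin-1-yl in place of 2-carboxypiperidin-1-yl on a saturated chain carbon bound to an aromatic carbon. Among the compounds with values here, no measured step shares this change; the two steps that start from compound 1 alter the same place and both leave the read-out unreadable, while the one numeric value, that of compound 3, sits close to the limit. The expected step that the limit leaves unreadable from compound 1 to compound 4 is therefore taken to be no more than a move within the same region. Compound 4 is estimated at 55000 nM, within 35000 nM to 90000 nM, and the assay is expected most likely to report again only a limit.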

Compound 4, half-maximal inhibitory concentration: > 50000 nM
Compound 4: no number, only a limit (the forecaster's own chance of this, stated with the estimate: 70%); the middle value does not contradict the limit.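

For the compounds shown here, the steps linking compound 4 to compound 1, compound 2 and compound 3 cannot be read, so the result adds no sized step: the limit of > 50000 nM in this assay, at which 3 of the 4 values shown sit.

The compounds shown leave open how far compound 1, compound 2 and compound 4 actually differ from one another or from compound 3 in this assay.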